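The source may report more compounds than this note shows. Statements on the series, on what has been measured and on what is new or still open speak of the compounds shown alone.

Measured in a functional assay on KB cells (Homo sapiens) for antiproliferative activity, read by MTT assay, with a stated time of 72 h; on this read-out higher numbers stand for weaker inhibition and lower numbers for stronger inhibition:

Compound 1 `COc1ccc(-c2sc(C(=O)O)cc2-c2cc(OC)c(OC)c(OC)c2)cc1`: 10400 nM.
Compound 2 `COc1cc(-c2cc(C(=O)O)sc2-c2cccc(Br)c2)cc(OC)c1OC`: 32300 nM.
Compound 3 `COc1ccc(-c2sc(C(=O)O)cc2-c2cc(OC)c(OC)c(OC)c2)cc1OCc1ccccc1`: > 100000 nM, a limit and not a number.

On these data alone, compound 3 has the highest reading of the three, so it shows the weakest inhibition here, though its true value is unknown. Compound 4 `COc1ccc(-c2sc(C(=O)O)cc2-c2cc(OC)c(OC)c(OC)c2)cc1O` puts hydrogen in place of benzyl on an oxygen on an aromatic ring, turning benzyloxy into hydroxy (hydrogen in place of benzyl on an oxygen on an aromatic ring). The most relevant measurement is an at least 9.6-fold higher number from compound 1 to compound 3 (0.98 log units; beyond the scatter), where benzyloxy came in place of hydrogen on an aromatic carbon and the number rose. Compound 4 removes the benzyl part of that same group, so some of that rise is expected to be undone. The other measured change, a 3.1-fold higher number from compound 1 to compound 2 (0.49 log units; beyond the scatter), was modest, which suggests that compound 4 will stay in the same broad range as compound 1 and compound 2. A drop in the number is therefore expected, meaning stronger inhibition, with an estimated size of an at least 6.6-fold lower number from compound 3 to compound 4 (0.82 log units; beyond the scatter). For compound 4 the estimate is 15000 nM, with an expected range of 4000 nM to 60000 nM.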

Compound 4, half-maximal inhibitory concentration: 11200 nM
Compound 4: the middle estimate sits 1.3-fold (0.13 log units) above what was measured; the measured number falls inside the stated range.
By their numbers in this assay, from the lowest: compounds 1 and 4 (each within the scatter of the next); then compound 2. At a limit, above all of these: compound 3.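

Taking the benzyl off the oxygen restores a measurable reading, an at least 8.9-fold lower number from compound 3 to compound 4 (0.95 log units; beyond the scatter), so the benzyloxy group as a whole does not tolerate this position, while the oxygen alone on the aromatic ring does. The size of that step has only a floor, since compound 3 is held by a limit and not a number: the limit of > 100000 nM in this assay, at which 1 of the 4 values shown sits.

Hydroxy in place of hydrogen on the aromatic carbon leaves the reading within the scatter, a 1.1-fold higher number from compound 1 to compound 4 (0.03 log units; within the scatter), and the modest gap to the bromine compound stays in place, a 2.9-fold lower number from compound 2 to compound 4 (0.46 log units; beyond the scatter).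

On these data alone, whether a methyl or ethyl on this oxygen would stay with compound 4 or move towards the limit of compound 3 remains open. So does the reading with an amine in place of the hydroxy.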